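Swapping a dibromophenyl amide for a methoxyphenyl amide

The compounds below may be only part of what the source reports. "The series", "measured", "known", "first", "only" and "open" are said of these compounds alone.

The measured compounds, each with its result in an assay for inhibition of HSP60/HSP10 (Homo sapiens), with a stated time of 60 min; a lower number here means a stronger inhibitor, a higher number a weaker inhibitor:
- Compound 1 `O=C(Nc1ccc(Sc2nc3ccccc3s2)c(Cl)c1)c1cc(Br)cc(Br)c1` gives > 100000 nM, which is a limit of the assay rather than a number.
- Compound 2 `O=C(Nc1cccc(Cl)c1)c1cc(Br)cc(Br)c1` gives > 100000 nM, again a limit.
- Compound 3 `O=C(Nc1ccc(Sc2nc3ccccc3s2)cc1)c1cc(Br)cc(Br)c1` gives > 100000 nM, again a limit.

Compound 1 therefore stands at the limit of this assay, and so do the other two measured compounds: the limit of > 100000 nM in this assay, at which 3 of the 3 values shown sit. Within the data shown here, the one step that joins two measured compounds, a step that the two limits leave unreadable from compound 1 to compound 3, cannot be sized, since both ends are limits.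

Compound 4 `COc1ccccc1C(=O)Nc1ccc(Sc2nc3ccccc3s2)c(Cl)c1` differs from compound 1 in one place: 2-methoxyphenyl in place of 3,5-dibromophenyl on a carbonyl carbon. No measured step concerns this position, so none of the steps shown bears on it, and the three limits give only a floor of weak activity to start from. Without a readable step, the expected change in this assay cannot be placed in either direction beyond the scatter, and the most likely outcome is another limit. The estimated step of a number no higher from compound 1 to compound 4 (the limit leaves the size open) is therefore expected to be close to none. Compound 4 is estimated at 100000 nM, with a range from 20000 nM to 500000 nM.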

Compound 4, half-maximal inhibitory concentration: > 100000 nM
Compound 4 gave a limit, no number; the forecaster's own chance of this, stated with the estimate: 80%; the middle value sits exactly at the limit.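

In this assay compound 4 gives > 100000 nM as a limit and not a number. Compound 1 also sits at a limit, so no step can be read between compound 1 and compound 4: the limit of > 100000 nM in this assay, at which 4 of the 4 values shown sit. The compounds shown leave open which change to these structures, if any, would give a readable value in this assay and how large that step would be.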